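The source may hold more compounds than are shown below. What is called first, only, known or untested is meant among the compounds shown, and "the series" means these compounds.

In a functional assay on K562 cells (Homo sapiens) for cytotoxicity, read by MTT assay, with a stated time of 72 h (a lower number here means a stronger inhibitor, a higher number a weaker inhibitor), compound 1 `CC1=CCC[C@H]2[C@](C)(CC3=CC(=O)C=C(N[C@@H](CC(C)C)C(=O)O)C3=O)[C@@H](C)CC[C@]12C` gives 11200 nM and so stands level, within the scatter, with compound 2 `CC(C)(C)C1=CC(=O)C=CC1=O` at 15500 nM and clearly lower than compound 3 `CC(C)C[C@H](NC1=CC(=O)C=C(C(C)(C)C)C1=O)C(=O)O` at 76500 nM on this scale. Compound 4 `CC1=CCC[C@H]2[C@](C)(CC3=CC(=O)C=C(N[C@@H](C)C(=O)O)C3=O)[C@@H](C)CC[C@]12C` keeps the core of compound 1 and changes one side chain, with hydrogen in place of isopropyl on a saturated chain carbon, two bonds along the chain from an amine nitrogen and a carbonyl carbon as the counted difference: hydrogen in place of isopropyl on a saturated chain carbon, which turns isobutyl to methyl. Among the measured compounds shown here, no measured pair in this assay shows this change, so only a loose expectation is possible: a modest rise in the number, not far beyond the scatter. The estimated change is a 1.6-fold higher number from compound 1 to compound 4 (0.21 log units; within the scatter) on this reading. For compound 4 the estimate is 18000 nM with 8000 nM to 45000 nM as its expected range.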

Compound 4, half-maximal inhibitory concentration: 15800 nM
Compound 4: the middle estimate sits 1.1-fold (0.06 log units) above what was measured, within the range that was stated.
By their numbers in this assay, from the lowest: compounds 1, 2 and 4 (each within the scatter of the next); then compound 3.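

In this assay the step from isobutyl to methyl, with hydrogen in place of isopropyl on a saturated chain carbon, gives a 1.4-fold higher number from compound 1 to compound 4 (0.15 log units; within the scatter) and so stays within the scatter. Among the compounds shown here, this is the first comparison that isolates this side chain, and it shows that the cell result holds when these three carbons are removed. Nothing available explains this result. Still open, going by these compounds, is whether a longer chain, a phenyl ring or an added amine on this side chain would shift the number beyond the scatter.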